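From Iodo to Methoxy in a Growth Inhibition Series

A few compounds are considered here, and "the series" means these few. Any claim that something is new, unique, unknown or untested is made for them only; others in the source may bear on it.

In a functional assay on MCF7 cells (Homo sapiens) for inhibition (on this read-out higher numbers stand for weaker inhibition of growth and lower numbers for stronger inhibition of growth), compound 1 (`NC(=O)c1cc(Cl)ccc1NC(=O)COc1ccccc1`) gives 1810 nM and compound 2 (`NC(=O)c1cc(I)ccc1NC(=O)COc1ccccc1`) gives 230 nM as the lower of the two numbers. Compound 3 (`COc1ccc(NC(=O)COc2ccccc2)c(C(N)=O)c1`) carries methoxy in place of iodo on an aromatic carbon. For the measured compounds named here, the only measured step at this place, iodo in place of chloro, is a 7.9-fold lower number from compound 1 to compound 2 (0.90 log units; beyond the scatter) and it is a modest one. Going by the values given here, no measured compound carries methoxy, so this guide is weak. In this assay a higher number is expected, an estimated 5.7-fold higher number from compound 2 to compound 3 (0.75 log units; beyond the scatter) and similar in size to that step. The expected value for compound 3 is 1300 nM with a range of 350 nM to 4500 nM around it.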

Compound 3, concentration for 50% growth inhibition: 497 nM
The estimate for compound 3 lay 2.6-fold (0.42 log units) above the measured number; the range from low to high includes it.
By their numbers in this assay, from the lowest: compound 2; then compound 3; then compound 1.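

In this assay, this position does not need a halogen for growth inhibition: swapping iodo for methoxy gives a 2.2-fold higher number from compound 2 to compound 3 (0.33 log units; beyond the scatter), while swapping chloro for methoxy gives a 3.6-fold lower number from compound 1 to compound 3 (0.56 log units; beyond the scatter). Methoxy therefore places compound 3 between the two halogen compounds, even though it alone brings a hydrogen-bond acceptor, so that count does not by itself set the order. Nothing available explains this order.

From the compounds shown here alone, whether bromo, an amine or a carboxylic acid would fall within the same span remains open. So does whether this order holds in other cell lines.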